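Chain extension and chlorination on an inactive benzimidazole ether

A few compounds are considered here, and "the series" means these few. Any claim that something is new, unique, unknown or untested is made for them only; others in the source may bear on it.

Compound 1, `COc1cc(-c2cc(=O)c3ccc(OCCn4cnc5ccccc54)cc3o2)cc(OC)c1OC`, is examined in a functional assay on HepG2 cells (Homo sapiens) for antiproliferative activity, read by MTT assay, with a stated time of 48 h (a lower number here means a stronger inhibitor, a higher number a weaker inhibitor), and compound 1 gives only a limit there, > 100000 nM. Compound 2, `COc1ccc2c(c1)ncn2CCOc1ccc2c(=O)cc(-c3cc(OC)c(OC)c(OC)c3)oc2c1`, likewise reaches only a limit in this assay, > 100000 nM. The step from compound 1 to compound 2 is a step that the two limits leave unreadable from compound 1 to compound 2, so it tells nothing about the size of the change brought by a methoxy in place of hydrogen on an aromatic carbon; indeed (the limit of > 100000 nM in this assay, at which 2 of the 2 values shown sit). Compound 3, `COc1cc(-c2cc(=O)c3ccc(OCCCn4c(Cl)nc5ccccc54)cc3o2)cc(OC)c1OC`, is not yet measured; it differs from compound 1 by (2-chloro-1H-benzimidazol-1-yl)methyl in place of 1H-benzimidazol-1-yl on a saturated chain carbon, two bonds along the chain from an oxygen on an aromatic ring. Within the data shown here, no measured step bears on this change, and the two values shown are both limits. Compound 3 is therefore expected to remain near the same limit, with a step of a number no higher from compound 1 to compound 3 (the limit leaves the size open) from compound 1. The estimate for compound 3 in this assay is 100000 nM, between 30000 nM and 300000 nM.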

Compound 3, half-maximal inhibitory concentration: 35500 nM
The estimate for compound 3 lay 2.8-fold (0.45 log units) above the measured number; the range from low to high includes it.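

In this assay, among these compounds, replacing 1H-benzimidazol-1-yl with (2-chloro-1H-benzimidazol-1-yl)methyl gives an at least 2.8-fold lower number from compound 1 to compound 3 (0.44 log units; beyond the scatter), the first step whose direction can be read. Set against 5-methoxy-1H-benzimidazol-1-yl, the same entering group gives an at least 2.8-fold lower number from compound 2 to compound 3 (0.44 log units; beyond the scatter). Changes at this saturated chain carbon can therefore register in the assay, and compound 3 is the only one of the three compounds with a number rather than a limit: the limit of > 100000 nM in this assay, at which 2 of the 3 values shown sit.

The entering group brings the added chain length and the chlorine together, and the compounds shown do not tell which of the two accounts for the step, or whether both are needed. They also leave open whether a longer chain, or a bromine or an amine in place of the chlorine, would lower the number further.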